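This account rests on a few compounds, and the source may have more. Where it says the series, first, only, none or still open, it means among the compounds named here.

Measured compounds in the series:
- compound 1, `O=C(NO)c1ccc(NCc2nc(-c3ccc(Cl)cc3)nn2-c2ccccc2)cc1`: 181 nM
- compound 2, `O=C(NO)c1ccc(NCc2nc(-c3ccc(F)cc3)nn2-c2ccccc2)cc1`: 115 nM
- compound 3, `O=C(NO)c1ccc(NCc2nc(-c3cc4ccccc4s3)nn2-c2ccccc2)cc1`: 324 nM

All three share the same core and differ only in the aryl group on the five-membered ring. In an assay on Sf9 cells for inhibition of protein deacetylase HDAC6 (Homo sapiens), read by fluorescence, with a stated time of 40 min (a higher number here means a weaker inhibitor, a lower number a stronger inhibitor), compound 3 carries the highest of the three numbers. One of the two steps that lead to it is a 1.8-fold higher number from compound 1 to compound 3 (0.25 log units; within the scatter), so those two compounds sit within the scatter of each other; the other is a 2.8-fold higher number from compound 2 to compound 3 (0.45 log units; beyond the scatter), a modest but real step. Compound 1 and compound 2 themselves lie close: a 1.6-fold lower number from compound 1 to compound 2 (0.20 log units; within the scatter).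

Compound 4, `Cc1ccc(-c2nc(CNc3ccc(C(=O)NO)cc3)n(-c3ccccc3)n2)s1`, is the next member to be measured in this assay. The change from compound 3 is 5-methylthiophen-2-yl in place of 1-benzothiophen-2-yl on an aromatic carbon. Going by the values given here, no measured pair exchanges one sulfur-containing ring for another, so the closest guide is the pair of steps that swap the aryl group at this same carbon, from compound 1 to compound 3 and from compound 2 to compound 3, both of which moved the number by less than a factor that would count as large. Replacing the larger fused ring by a smaller single ring is expected to move the number, if at all, back toward the values of compound 1 and compound 2, so a small downward step or none beyond the scatter is anticipated. Compound 4 is thus expected to give about 200 nM, within a range of 90 nM to 450 nM. The expected step is a 1.6-fold lower number from compound 3 to compound 4 (0.21 log units; within the scatter).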

Compound 4, half-maximal inhibitory concentration: 30.6 nM
The estimate for compound 4 lay 6.5-fold (0.82 log units) above the measured number, and the stated range ends above it.
By their numbers in this assay, from the lowest: compound 4; then compounds 2, 1 and 3 (each within the scatter of the next, the first and the last beyond it).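

In this assay, the aryl group at this carbon of the shared core can move the number much further than the earlier swaps showed, with 5-methylthiophen-2-yl in place of 1-benzothiophen-2-yl giving an 11-fold lower number from compound 3 to compound 4 (1.02 log units; beyond the scatter) as a large step. The change does more than undo the effect of the fused ring, since the series also shows a 3.8-fold lower number from compound 2 to compound 4 (0.57 log units; beyond the scatter) and a 5.9-fold lower number from compound 1 to compound 4 (0.77 log units; beyond the scatter) as modest steps beyond the scatter, which makes compound 4 the strongest inhibitor of the four in this series. No measurement here accounts for the size of these steps.

The change from 1-benzothiophen-2-yl exchanges the fused ring for a single ring and adds a methyl in one move, so the compounds shown cannot separate the two, and a plain thiophen-2-yl group would be the direct test. Also open, on these data alone, is how far the methyl itself can be varied, for instance whether an ethyl group, a longer chain or an amine in its place holds the number of compound 4.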